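Working notes on the step to compound 3

The compounds below may be only part of what the source reports. "The series", "measured", "known", "first", "only" and "open" are said of these compounds alone.

Measured so far in an ADME assay on CCRF-CEM cells (Homo sapiens) for cytotoxicity, read by MTT assay, with a stated time of 72 h (a lower number here means that less compound is tolerated, a higher number that more compound is tolerated), for this series:
- compound 1 `CC(=O)c1c(O)c(C(C)=O)c(O)c(C(c2c(O)c(C(C)=O)c(O)c(C(C)=O)c2O)C2CCCCC2)c1O` gives 58900 nM
- compound 2 `CC(C)CC(=O)c1c(O)c(C(=O)CC(C)C)c(O)c(C(c2ccc(O)cc2)c2c(O)c(C(=O)CC(C)C)c(O)c(C(=O)CC(C)C)c2O)c1O` stands as "not determined" (no result reported)

Among the measured compounds shown here, compound 1 holds the only number in the set, so it cannot yet be ranked against any other compound. Compound 2 offers no comparison.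

Compound 3 `CC(=O)c1c(O)c(C(C)=O)c(O)c(C(c2ccc(N(C)C)cc2)c2c(O)c(C(C)=O)c(O)c(C(C)=O)c2O)c1O` is still unmeasured. It keeps the core of compound 1 and carries 4-(dimethylamino)phenyl in place of cyclohexyl on a saturated chain carbon bound to two aromatic carbons. The counted change is 4-(dimethylamino)phenyl in place of cyclohexyl on a saturated chain carbon bound to two aromatic carbons and nothing else differs.

For the measured compounds named here, the series offers no step between measured compounds, so no precedent gives the size of this change. In this assay a small move towards less compound being tolerated is expected, hardly beyond the usual scatter, and even its direction is uncertain. Going by the values given here, the only anchor is compound 1 at 58900 nM and the expectation stays close to it. The estimated change is a 1.5-fold lower number from compound 1 to compound 3 (0.17 log units; within the scatter) on this reading. For compound 3 the expected value is 40000 nM with an estimated range from 12000 nM to 130000 nM once the measurement is made.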

Compound 3, half-maximal cytotoxic concentration: 22100 nM
Compound 3: middle estimate off by 1.8-fold (0.26 log units), on the high side, and the stated range covers the measured number.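

In this assay, among the compounds shown here, the step of a 2.7-fold lower number from compound 1 to compound 3 (0.43 log units; beyond the scatter) is the first size on record for a change on a saturated chain carbon bound to two aromatic carbons, as the earlier compounds gave only one number and no comparison. It shows that this position does not ignore the exchange of cyclohexyl for 4-(dimethylamino)phenyl, and that the direction of this single step is towards less compound being tolerated, by a modest amount beyond the scatter. The exchange replaces a non-aromatic ring with an aromatic one and adds a nitrogen in the same move, and no measurement bears on which part of it matters.

The compounds shown leave open whether the step follows the aromatic ring alone or needs the dimethylamino group, a question that a plain phenyl on the same carbon would address. They also leave open how a 4-methoxyphenyl or a 4-carboxyphenyl would compare at this position, and so whether this one pair marks a trend or an isolated result.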